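A Phenol Exchanged for a Ketone on the Chain

This account rests on a few compounds, and the source may have more. Where it says the series, first, only, none or still open, it means among the compounds named here.

Compound 1 `NS(=O)(=O)O[C@@H]1[C@H](O)C[C@@H](O)C[C@H]1OCCCCc1ccccc1O`: in an assay on isolated protein for inhibition of inositol monophosphatase 1 (Bos taurus) (on this read-out higher numbers stand for weaker inhibition and lower numbers for stronger inhibition), compound 1 gives > 300000 nM, a limit of the assay.
Compound 2 `CC(=O)NS(=O)(=O)O[C@@H]1[C@H](O)C[C@@H](O)C[C@H]1OCCCCc1ccccc1O`: in this assay compound 2 gives > 300000 nM, again a limit of the assay.

Within the data shown here, compound 1 therefore stands nowhere on a numerical scale in this assay; it is known only by a limit, and the one further value shown is a limit as well, so compound 1 and compound 2 cannot be ordered against each other. Among the measured compounds shown here, the single measured step, a step that the two limits leave unreadable from compound 1 to compound 2, acetyl in place of hydrogen on a sulfonamide nitrogen, is left unreadable, both values sitting at the limit of > 300000 nM in this assay, at which 2 of the 2 values shown sit.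

Compound 3 `NS(=O)(=O)O[C@@H]1[C@H](O)C[C@@H](O)C[C@H]1OCCCCC1CCCCC1=O` differs from compound 1 by 2-oxocyclohexyl in place of 2-hydroxyphenyl on a saturated chain carbon, four bonds along the chain from an oxygen on a saturated carbon. No measured step touches this part of the molecule, and the one step shown is unreadable, so nothing supports expecting a readable gain. Compound 3 is therefore expected to remain at the limit as well, an estimated step of a number no higher from compound 1 to compound 3 (the limit leaves the size open). Compound 3 is estimated at 300000 nM, within a range from 30000 nM to 3000000 nM.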

Compound 3, half-maximal inhibitory concentration: 200000 nM
The estimate for compound 3 lay 1.5-fold (0.18 log units) above the measured number; low and high end bracket the measured number.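

In this assay, among these compounds, compound 3 is the first compound here to carry a number rather than a limit, and it shows that this end of the chain can be changed with a readable result. The change to 2-oxocyclohexyl gives an at least 1.5-fold lower number from compound 1 to compound 3 (0.17 log units; that floor lies within the scatter), so only a floor on the size of the step is known, and that floor cannot separate it from repeat-measurement noise. A readable number is reached without the aromatic ring or the hydrogen-bond donor of 2-hydroxyphenyl, although the series as a whole remains close to its ceiling: the limit of > 300000 nM in this assay, at which 2 of the 3 values shown sit.

Going by these compounds, whether an amine or a carboxylic acid in place of the ketone, or a longer chain, would move the number further remains open. On these data alone, it is also open whether 2-oxocyclohexyl would tolerate acetyl on the sulfonamide nitrogen.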